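Two Chalcone-Type Sulfur Compounds and an Untested Dichloro Analogue

The source may hold more compounds than are shown below. What is called first, only, known or untested is meant among the compounds shown, and "the series" means these compounds.

Measured so far:
compound 1, `Cc1ccc(CS/C(=C/c2ccc(F)c(C)c2)C(=O)c2ccc(Cl)cc2)cc1`, 25000 nM
compound 2, `O=C(/C(=C\c1ccc(Cl)cc1Cl)S(=O)(=O)c1ccc(Br)cc1)c1ccc(Br)cc1`, 10000 nM

In a functional assay on DU-145 cells (Homo sapiens) for inhibition, read by trypan blue exclusion, with a stated time of 96 h (a higher number here means a weaker inhibitor of growth, a lower number a stronger inhibitor of growth), compound 1 gives the highest number of the two, so of the pair it is the weaker inhibitor of growth; compound 2 sits at a lower number, a gap beyond the scatter. Compound 3, `Cc1ccc(CS/C(=C/c2cccc(Cl)c2Cl)C(=O)c2ccc(Cl)cc2)cc1`, differs from compound 1 in one place: 2,3-dichlorophenyl in place of 4-fluoro-3-methylphenyl on a double-bonded chain carbon bound to a double-bonded chain carbon. For the measured compounds named here, no measured pair shows this change, so a small step, if any, is expected, leaning toward a lower number. The expected step is a 1.7-fold lower number from compound 1 to compound 3 (0.22 log units; within the scatter). Compound 3 is estimated at 15000 nM, within 5000 nM to 50000 nM.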

Compound 3, concentration for 50% growth inhibition: 25000 nM
The estimate for compound 3 lay 1.7-fold (0.22 log units) below the measured number, and the stated range covers the measured number.
By their numbers in this assay, from the lowest: compound 2; then compounds 1 and 3 (each within the scatter of the next).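

In this assay, putting 2,3-dichlorophenyl in place of 4-fluoro-3-methylphenyl on a double-bonded chain carbon bound to a double-bonded chain carbon gives no change at the digits printed from compound 1 to compound 3 (within the scatter). This is the only direct reading of this position among the compounds shown, and it indicates that these two substituted phenyl groups can be exchanged here without a difference beyond the scatter. No separate measurement bears on this result.
Still open, from the compounds shown here alone, is whether a phenyl ring carrying an amine or a carboxylic acid at this position would give a different number. Also open, going by these compounds, is whether any other group here could move the number beyond the scatter.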